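Swapping Methyl for Amino on a Sulfonyl Sulfur

A few compounds are considered here, and "the series" means these few. Any claim that something is new, unique, unknown or untested is made for them only; others in the source may bear on it.

Of the compounds shown here, three sharing one core have been measured in a functional assay on PC-3 cells (Homo sapiens) for antiproliferative activity, read by MTT assay, with a stated time of 72 h; on this read-out higher numbers stand for weaker inhibition and lower numbers for stronger inhibition. Compound 1 `CC(=O)Oc1ccc(/C=C/C(=O)OCCSc2nc(-c3ccc(S(C)(=O)=O)cc3)n(-c3ccc(F)cc3)n2)cc1OC(C)=O` gives 15700 nM, compound 2 `CC(=O)Oc1ccc(/C=C/C(=O)OCCSc2nc(-c3ccc(S(C)(=O)=O)cc3)n(-c3ccc(C(F)(F)F)cc3)n2)cc1OC(C)=O` gives 14500 nM, and compound 3 `CS(=O)(=O)c1ccc(-c2nc(SCCOC(=O)/C=C/c3ccc(O)c(O)c3)nn2-c2ccccc2)cc1` gives 14600 nM. Compound 3 stands second highest of the three numbers, yet its gap to compound 2 and its gap to compound 1 are both within the scatter, so the three cannot be told apart.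

Within the data shown here, the only step between measured compounds that differ in one place is a 1.1-fold lower number from compound 1 to compound 2 (0.03 log units; within the scatter), a change elsewhere on the shared core that left the number essentially unchanged. Compound 4 `NS(=O)(=O)c1ccc(-c2nc(SCCOC(=O)/C=C/c3ccc(O)c(O)c3)nn2-c2ccccc2)cc1` differs from compound 3 by amino in place of methyl on a sulfonyl sulfur. Among the measured compounds shown here, no measured step touches this position, so nothing here points to a shift in either direction, and the one measured change gave none. The step expected from compound 3 to compound 4 is no change at the digits printed from compound 3 to compound 4 (within the scatter), nothing beyond the scatter. Compound 4 is therefore estimated at 14600 nM, within a range from 5000 nM to 40000 nM.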

Compound 4, half-maximal inhibitory concentration: 15000 nM
Compound 4: middle estimate off by 1.0-fold (0.01 log units), on the low side; measured number inside the range.
By their numbers in this assay, from the lowest: compounds 2, 3, 4 and 1 (each within the scatter of the next).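

In this assay, the swap that turns 4-(methylsulfonyl)phenyl into 4-sulfamoylphenyl gives a 1.0-fold higher number from compound 3 to compound 4 (0.01 log units; within the scatter), a step within the scatter. Among these compounds, this is the first measured step at the sulfonyl sulfur, and it shows that exchanging methyl for amino, which by count adds a hydrogen-bond donor, leaves the two compounds indistinguishable on this read-out. Nothing available explains this result.

Open, going by these compounds, is whether a larger group on the sulfonyl sulfur, such as a dimethylamino group or a longer chain like butyl, would separate from compound 3 by more than the scatter. Also open, on these data alone, is whether the same exchange would read the same way on the core of compound 1, which carries acetate esters and a fluoro group.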